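A few compounds are considered here, and "the series" means these few. Any claim that something is new, unique, unknown or untested is made for them only; others in the source may bear on it.

In a functional assay for inhibition, with Sus scrofa as the target (a higher number here means a weaker inhibitor, a lower number a stronger inhibitor), compound 1 `CC1(C)Oc2ccc(C#N)cc2[C@@H](n2ccccc2=O)[C@@H]1O` gives 300 nM, and compound 2 `CC1(C)Oc2ccc(C#N)cc2[C@@H](N2CCCC2=O)[C@]1(C)O` gives 4000 nM. Compound 3 `CC1(C)Oc2ccc(C#N)cc2[C@@H](On2ccccc2=O)[C@]1(C)O` reads > 100000 nM, which is a limit of the assay and not a number. Its position in the series is therefore bounded on one side only.

Compound 4 `CC1(C)Oc2ccc(C#N)cc2[C@@H](Oc2ccnc(O)c2)[C@]1(C)O` has the same atoms as compound 3, joined differently: a group of 7 heavy atoms (5 carbon, 1 nitrogen, 1 oxygen; one six-membered aromatic ring with 1 hetero atom) in place of a group of 7 heavy atoms (5 carbon, 1 nitrogen, 1 oxygen; one six-membered aromatic ring with 1 hetero atom), on an oxygen on a saturated carbon. The 2-hydroxypyridin-4-yl group now stands on an oxygen on a saturated carbon.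

Among the measured compounds shown here, the one measured step that bears on this change is an at least 25-fold higher number from compound 2 to compound 3 (1.39 log units; beyond the scatter), which is large and beyond the scatter. For the measured compounds named here, it involves a different group on a saturated ring carbon, so it shows the possible size of a change in this region and is no direct precedent for this exchange. With compound 2 at 4000 nM as the nearest reference with a number, a large move towards a lower number is expected. The expected step is an at least 20-fold lower number from compound 3 to compound 4 (1.30 log units; beyond the scatter) in this assay. For compound 4 the estimated value is 5000 nM, with an expected range of 500 nM to 60000 nM.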

Compound 4, half-maximal inhibitory concentration: 4 nM
Estimate against measurement, compound 4: 1300-fold (3.10 log units) above, and the stated range ends above it.
By their numbers in this assay, from the lowest: compound 4; then compound 1; then compound 2. At a limit, above all of these: compound 3.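

In this assay, the same atoms joined differently on an oxygen on a saturated carbon give an at least 25000-fold lower number from compound 3 to compound 4 (4.39 log units; beyond the scatter), so at this position the way the ring is built and attached decides the result, not its atom count. Among the compounds shown here, measured against the group on the saturated ring carbon of compound 2, the oxygen-linked 2-hydroxypyridin-4-yl group gives a 1000-fold lower number from compound 2 to compound 4 (3.00 log units; beyond the scatter), which shows that this position tolerates far more than the earlier compounds indicated. The first of these steps is only a bound, as the reading for compound 3 is a limit of the assay and not a number: the limit of > 100000 nM in this assay, at which 1 of the 4 values shown sits.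

The compounds shown do not separate the contribution of the hydroxyl from that of the ring nitrogen within the 2-hydroxypyridin-4-yl group. From the compounds shown here alone, how an amine or a methoxy group in place of that hydroxyl would read in this assay remains open.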